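A few compounds are considered here, and "the series" means these few. Any claim that something is new, unique, unknown or untested is made for them only; others in the source may bear on it.

Working notes on the amide series sharing the core of compound 2.

Compound 2 `Cc1cc(N2CCC(N3CCCC3C)C2)ccc1NC(=O)C1CC2CCC1C2` gives 19.9 nM in an assay on CHO cells for displacement of a labelled ligand from histamine receptor H3 (Macaca mulatta); a lower number here means a stronger inhibitor, a higher number a weaker inhibitor. Among the three measured compounds it holds the second highest number. Compound 1 `Cc1cc(N2CCC(N3CCCC3C)C2)ccc1NC(=O)C1C(C)(C)C1(C)C` gives 37.3 nM, and the step of a 1.9-fold lower number from compound 1 to compound 2 (0.27 log units; within the scatter) stays within the scatter. Compound 3 `Cc1cc(N2CCC(N3CCCC3C)C2)ccc1NC(=O)C1CCCO1` gives 7.34 nM, so the step of a 2.7-fold lower number from compound 2 to compound 3 (0.43 log units; beyond the scatter) is modest but real. The step of a 5.1-fold lower number from compound 1 to compound 3 (0.71 log units; beyond the scatter) rounds out the picture.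

Compound 4 `Cc1cc(N2CC[C@H](N3CCC[C@@H]3C)C2)ccc1NC(=O)C1CC2CCC1C2` carries the same atoms and bonds as compound 2; the difference is the two compounds have the same atoms and bonds; at least one stereo element is drawn with a configuration in one of them and without one in the other: 2 of 5 stereo elements differ; a stereocentre at a saturated ring carbon is drawn without a configuration in compound 2 and S in compound 4; a stereocentre at a saturated ring carbon is drawn without a configuration in compound 2 and S in compound 4. For the measured compounds named here, none of the measured steps concerns a change in drawn configuration; all three exchange the group on the carbonyl carbon. The expectation therefore rests on compound 2 alone: if the drawn configuration is the one that carries the measured value of compound 2, no step beyond the scatter is expected, and if not, a lower number is expected. For compound 4 the estimate is 12 nM, with a range from 4 nM to 40 nM. The expected step of a 1.7-fold lower number from compound 2 to compound 4 (0.22 log units; within the scatter) is thus small and toward a lower number.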

Compound 4, inhibition constant: 0.55 nM
Compound 4: the middle estimate sits 22-fold (1.34 log units) above what was measured; measured number below the stated range.
By their numbers in this assay, from the lowest: compound 4; then compound 3; then compounds 2 and 1 (each within the scatter of the next).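

The step of a 36-fold lower number from compound 2 to compound 4 (1.56 log units; beyond the scatter) in this assay involves no change in atoms or bonds, yet it exceeds every step seen among the exchanges on the carbonyl carbon, the largest of which was a 5.1-fold lower number from compound 1 to compound 3 (0.71 log units; beyond the scatter). Drawn configuration at these two saturated ring carbons therefore emerges as a stronger handle in this series than the amide group, which the earlier compounds could not show. The only difference to which this step can be tied is the following: the fact that one of compounds 2 and 4 is drawn with a defined configuration and the other without, at the place where they differ

Still open, from the compounds shown here alone, are which of the two S centres carries the gain, how forms drawn R at either centre behave, and how the stereo elements left undrawn in compound 4 contribute. It is also unknown whether the same drawn configuration would give a similar gain with oxolan-2-yl, or with a carboxylic acid or a longer chain, on the carbonyl carbon.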